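The source may report more compounds than this note shows. Statements on the series, on what has been measured and on what is new or still open speak of the compounds shown alone.

Measured in an ADME assay on Huh7.5.1 cells (Homo sapiens) for cytotoxicity, read by WST assay, with a stated time of 48 h; a higher number here means that more compound is tolerated, a lower number that less compound is tolerated:
- Compound 1 `Cc1c(-c2ccc(Oc3ccc(N4CCCCC4)cc3)c(F)c2)[nH]c2cccc(F)c2c1=O`: > 10000 nM (a limit)
- Compound 2 `CCN(C)c1ccc(Oc2ccc(-c3[nH]c4cccc(F)c4c(=O)c3C)cc2F)cc1`: > 10000 nM (a limit)
- Compound 3 `CCNc1ccc(Oc2ccc(-c3[nH]c4cccc(F)c4c(=O)c3C)cc2F)cc1`: > 10000 nM (a limit)

Compound 3 has no numerical value on this assay, only the limit > 10000 nM. The same holds across the series: the limit of > 10000 nM in this assay, at which 3 of the 3 values shown sit.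

Next is compound 4 `Cc1c(-c2ccc(Oc3ccc(N4CCNCC4)cc3)c(F)c2)[nH]c2cccc(F)c2c1=O`, which has piperazin-1-yl in place of ethylamino on an aromatic carbon of a six-membered aromatic ring of carbon only, para to a large group: piperazin-1-yl in place of ethylamino on an aromatic carbon.

Within the data shown here, three measured steps bear on this change. Two exchange the amino group on an aromatic carbon: a step that the two limits leave unreadable from compound 1 to compound 3 and a step that the two limits leave unreadable from compound 1 to compound 2. The third removes a methyl from the nitrogen: a step that the two limits leave unreadable from compound 2 to compound 3. None of them gives a size, so they support no expected direction and no step beyond the scatter.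

Compound 1, with piperidin-1-yl on an aromatic carbon, is the closest comparison, and its result is the limit > 10000 nM. A further result at the limit is therefore the most likely outcome for compound 4.

The expected change is a step that the limit leaves unreadable from compound 3 to compound 4, with no firm direction.

For compound 4 the estimated value is 12000 nM, with an expected range of 5000 nM to 30000 nM.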

Compound 4, half-maximal cytotoxic concentration: > 10000 nM
Compound 4: only a limit was reported; the forecaster's own chance of this, stated with the estimate: 80%; the middle value lies beyond the limit too.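

In this assay compound 4 gives > 10000 nM, which is a limit and not a number. No new step can be read between compound 4 and compound 1, compound 2 or compound 3. The compounds shown leave open whether these amino groups differ at all in this assay, and the series stands at a single value: the limit of > 10000 nM in this assay, at which 4 of the 4 values shown sit.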